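This account rests on a few compounds, and the source may have more. Where it says the series, first, only, none or still open, it means among the compounds named here.

Compound 1 `Cc1ccc(NC(=S)NC(=O)c2ccc(OCc3cccc(Cl)c3Cl)cc2)cc1-c1nc2ccccc2[nH]1`, compound 2 `O=C(NC(=S)Nc1ccc(Cl)c(-c2nc3ccccc3[nH]2)c1)c1ccc(OCc2ccc(Cl)c(Cl)c2)cc1` and compound 3 `Cc1ccc(NC(=O)NC(=O)c2ccc(OCc3ccccc3)cc2)cc1-c1nc2ccccc2[nH]1` share a core in which a benzimidazolyl-substituted aniline is tied through an acylthiourea or acylurea to a benzyloxybenzoyl group, and the fourth member, compound 4 `Cc1ccc(NC(=O)NC(=O)c2ccc(OCc3cccc(F)c3)cc2)cc1-c1nc2ccccc2[nH]1`, has not yet been tested. In a functional assay on MNK45 cells (Homo sapiens) for inhibition, read by MTT assay, with a stated time of 48 h (a higher number here means a weaker inhibitor, a lower number a stronger inhibitor), compound 1 gives only a limit, > 100000 nM, and not a number. In the same assay compound 2 gives 4600 nM. Compound 3, with an acylurea and an unsubstituted benzyloxy group, gives 35100 nM in this assay, the highest of the two numbers measured, and its gap to compound 2 lies beyond the usual scatter. For compound 1 only the limit of > 100000 nM in this assay, at which 1 of the 3 values shown sits, is known.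

The step from compound 3 to compound 4 is fluoro in place of hydrogen on an aromatic carbon, so that the benzyloxy group becomes a (3-fluorobenzyl)oxy group. Within the data shown here, no pair of measured compounds differs in just this way, so the size of the step cannot be read from the data; a single fluorine is a small change, and in this assay the step from compound 3 to compound 4 is expected to be a 1.2-fold lower number from compound 3 to compound 4 (0.07 log units; within the scatter), within the scatter. Compound 4 is therefore estimated at 30000 nM, expected between 10000 nM and 90000 nM.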

Compound 4, half-maximal inhibitory concentration: 53000 nM
Estimate against measurement, compound 4: 1.8-fold (0.25 log units) below, and the stated range covers the measured number.
By their numbers in this assay, from the lowest: compound 2; then compounds 3 and 4 (each within the scatter of the next). At a limit, above all of these: compound 1.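

Compound 3 and compound 4 form the first pair shown that differs in one place only, so the effect of a single substitution can now be read directly. In this assay, fluoro in place of hydrogen on an aromatic carbon of the benzyloxy group gives a 1.5-fold higher number from compound 3 to compound 4 (0.18 log units; within the scatter), so the two compounds cannot be told apart in this assay. At this carbon, then, a hydrogen and a fluoro give numbers that lie within the scatter of each other, and no measurement shown offers any explanation for that outcome.

Going by these compounds, it remains open whether a chloro, a methoxy group, an amine or a carboxylic acid at this same carbon would give a step beyond the scatter, and whether fluoro on another carbon of the same ring would read as it does here. Also open is what an acylthiourea in place of the acylurea does with everything else held constant, since no pair shown isolates that one difference.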